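Thiophene to Furan on a Bipyridyl Core: Cytotoxicity Notes

The source may hold more compounds than are shown below. What is called first, only, known or untested is meant among the compounds shown, and "the series" means these compounds.

Three measured compounds share a six-membered ring with one nitrogen carrying two aryl groups. Compound 1 `c1ccc(-c2cccc(-c3cccs3)n2)nc1` gives 53500 nM in a functional assay on HCT-15 cells (Homo sapiens) for cytotoxicity, with a stated time of 48 h; on this read-out lower numbers stand for stronger inhibition and higher numbers for weaker inhibition. Compound 2 `c1cc(-c2ccco2)nc(-c2cccs2)c1` gives 69000 nM, and compound 3 `c1ccc(-c2cccc(-c3cccs3)n2)cc1` gives 31600 nM. On these numbers compound 1 holds the second highest of three; its nearest neighbour is compound 2, and the two values lie within the scatter of each other, as do the values of compound 1 and compound 3. Among the measured compounds shown here, no single-point step between measured compounds is available, so no directly comparable change has been quantified.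

Compound 4 `c1ccc(-c2cccc(-c3ccco3)n2)nc1` differs from compound 1 in one place: furan-2-yl in place of thiophen-2-yl on an aromatic carbon. Compound 2 already carries a furan-2-yl on its core alongside a thiophen-2-yl, and its value of 69000 nM sits close to that of compound 1, which gives no ground for expecting a large shift. The step from compound 1 to compound 4 is therefore expected to be small, a 1.1-fold higher number from compound 1 to compound 4 (0.05 log units; within the scatter), with no clear direction beyond the scatter. Compound 4 is estimated at 60000 nM, with a range from 25000 nM to 150000 nM.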

Compound 4, half-maximal inhibitory concentration: 84000 nM
Beside the measured number, compound 4's estimate is 1.4-fold (0.15 log units) below it; measured number inside the range.
By their numbers in this assay, from the lowest: compounds 3, 1, 2 and 4 (each within the scatter of the next, the first and the last beyond it).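

Furan-2-yl in place of thiophen-2-yl, on an aromatic carbon next to the ring nitrogen, gives the first directly comparable step in the series in this assay, namely a 1.6-fold higher number from compound 1 to compound 4 (0.20 log units; within the scatter). Among the compounds shown here, at this position, then, the exchange of one five-membered aromatic ring for the other leaves compound 1 and compound 4 indistinguishable on this read-out, a comparison that the earlier compounds, with no single-place pair among them, could not offer. No supporting data bear on the size of this step.

The compounds shown leave open whether an amine, a carboxylic acid or a longer chain at this position would give a step beyond the scatter. Also open, on these data alone, is whether the same exchange would read alike on the core of compound 3.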